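This account rests on a few compounds, and the source may have more. Where it says the series, first, only, none or still open, it means among the compounds named here.

Measured in a functional assay on SK-BR-3 cells (Homo sapiens) for cytotoxicity, read by MTT assay, with a stated time of 72 h; a lower number here means that less compound is needed, a higher number that more compound is needed for the effect:
- compound 1 `COc1ccc(Nc2cc(C)oc(=O)c2)cc1`: > 30 uM
- compound 2 `COc1ccc(Nc2cc(-c3ccc4ccccc4c3)oc(=O)c2)cc1`: 0.13 uM

Compound 1 gives no number in this assay. Its entry of > 30 uM is a limit of the assay, and the record reads (the limit of > 30 uM in this assay, at which 1 of the 2 values shown sits). Compound 2 reads 0.13 uM, so a real number is available for one of the two measured compounds.

Compound 3 `COc1ccc(Nc2cc(C3CCCC3)oc(=O)c2)cc1` keeps the rest of compound 1 and carries cyclopentyl in place of methyl on an aromatic carbon, next to the ring oxygen: cyclopentyl in place of methyl on an aromatic carbon. Within the data shown here, no measured pair shows this change on its own, so the size of the step can only be judged loosely. The expectation of a fall rests on compound 2 at 0.13 uM, which shows that low numbers are reachable in this set. The expected change is a moderate fall in the number, estimated as an at least 4.2-fold lower number from compound 1 to compound 3 (0.63 log units; beyond the scatter), and it is counted from a limit. For compound 3 the estimate is 7 uM, with an expected range from 1.2 uM to 30 uM.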

Compound 3, concentration for half-maximal effect: 4.73 uM
The estimate for compound 3 lay 1.5-fold (0.17 log units) above the measured number; the measured number falls inside the stated range.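

In this assay, cyclopentyl in place of methyl on an aromatic carbon, next to the ring oxygen, gives an at least 6.3-fold lower number from compound 1 to compound 3 (0.80 log units; beyond the scatter). Among these compounds, this is the first reading of a single change at this position: a non-aromatic ring of carbon only, with no hydrogen-bond donors or acceptors, is enough to bring the shared core from no readable number to a measurable one, where compound 3 reads 4.73 uM. Compound 1 remains a limit of the assay at > 30 uM, so the step has a lower bound but no full size: the limit of > 30 uM in this assay, at which 1 of the 3 values shown sits.

The printed values also place compound 3 at 4.73 uM and compound 2 at 0.13 uM, but they do not say how much of the gain comes from the ring itself and how much from the carbon added at this position. A pentyl chain or a cyclohexyl ring at the same place would test that, and a piperidine or a carboxylic acid there would show whether anything other than carbon is accepted.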